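Swapping the Ring Amine for Diethylamino at the Quinoline Core

The source may hold more compounds than are shown below. What is called first, only, known or untested is meant among the compounds shown, and "the series" means these compounds.

Measured compounds:
- Compound 1, `CN(c1ccc2cc(NC(=O)CCc3ccc(C(F)(F)F)cc3)ccc2n1)C1CCCC1`: 2 nM
- Compound 2, `O=C(CCc1ccc(C(F)(F)F)cc1)Nc1ccc2nc(N3CCCC3)ccc2c1`: 3 nM; 3 nM (2 entries)
- Compound 3, `Nc1ccc2cc(NC(=O)CCc3ccc(C(F)(F)F)cc3)ccc2n1`: 240 nM

All three compounds share one core and are compared in an assay on isolated protein for displacement of a labelled ligand from melanin-concentrating hormone receptor 1 (Homo sapiens); on this read-out lower numbers stand for stronger inhibition and higher numbers for weaker inhibition. Compound 1 gives 2 nM, the lowest of the two single numbers recorded; compound 2 gives 3 nM; 3 nM (2 entries), which lies within the usual scatter of compound 1, so no order between them can be claimed. Compound 3, with a bare amino group in place of the cyclopentyl(methyl)amino group, is far weaker at 240 nM.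

Among the compounds with values here, the one step measured in one place is a 120-fold higher number from compound 1 to compound 3 (2.08 log units; beyond the scatter). It shows that removing both alkyl groups from the amine costs a great deal of binding.

Compound 4, `CCN(CC)c1ccc2cc(NC(=O)CCc3ccc(C(F)(F)F)cc3)ccc2n1`, has not yet been measured. It differs from compound 1 as follows: diethylamino in place of cyclopentyl(methyl)amino on an aromatic carbon. Both substituents remain dialkylamino groups of similar size, so the large loss seen on going to the bare amino in compound 3 is not expected to apply. Compound 2, which carries a different small amine at the same spot, also stays potent.

Compound 4 is therefore expected to give about 3 nM in this assay, in the range 1 nM to 10 nM, a step of a 1.5-fold higher number from compound 1 to compound 4 (0.18 log units; within the scatter) that is expected to lie within the scatter.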

Compound 4, half-maximal inhibitory concentration: 88 nM
Beside the measured number, compound 4's estimate is 29-fold (1.47 log units) below it, and the stated range ends below it.
By their numbers in this assay, from the lowest: compound 1; then compound 4; then compound 3.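

At this aromatic carbon, being a dialkylamino group is not enough for a low number in this assay: the change to diethylamino gives a 44-fold higher number from compound 1 to compound 4 (1.64 log units; beyond the scatter) even though the entering and leaving groups have the same counts of hydrogen-bond donors and acceptors, and neither carries a net charge. Diethylamino still improves on the bare amino group, with a 2.7-fold lower number from compound 3 to compound 4 (0.44 log units; beyond the scatter) as a modest step, so the low numbers among these four compounds belong only to the two amines that carry a ring, compound 1 and compound 2, and none of the four goes against this. Nothing available here explains the gap between these groups.

As far as these compounds go, it remains open whether the ring itself matters or only the size of the group, since diethylamino has both no ring and fewer heavy atoms than cyclopentyl(methyl)amino; a dipropylamino group, with no ring but more carbon, would help separate the two. Also open, from the compounds shown here alone, is how far the ring can change, for example to a piperidine or a morpholine.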